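Swapping a Furan for a Tert-Butyl Group

This account rests on a few compounds, and the source may have more. Where it says the series, first, only, none or still open, it means among the compounds named here.

Measured so far:
compound 1, `CCCn1c(=O)c2nc([C@@H]3CC4CCC3C4)[nH]c2n(CCC)c1=O`: 3.8 nM
compound 2, `CCCn1c(=O)c2nc(-c3ccco3)[nH]c2n(CCC)c1=O`: 560 nM

Both compounds were tested in an assay on cell membranes for binding affinity to adenosine receptor A1 (Cavia porcellus), read by radioligand binding; a lower number here means a stronger inhibitor, a higher number a weaker inhibitor. Compound 1 carries a group of two fused non-aromatic carbon rings on the shared core; compound 2 carries a furan-2-yl in the same place. Within the data shown here, compound 2 stands at the highest number of the two, the only other one being compound 1 with a 150-fold higher number from compound 1 to compound 2 (2.17 log units; beyond the scatter). Compound 3, `CCCn1c(=O)c2nc(C(C)(C)C)[nH]c2n(CCC)c1=O`, has not yet been measured in this assay. It differs from compound 2 by tert-butyl in place of furan-2-yl on an aromatic carbon. Among the measured compounds shown here, only one measured step bears on this change: the same position was swapped from a carbon-only ring group to a furan with a 150-fold higher number from compound 1 to compound 2 (2.17 log units; beyond the scatter). Going back to a carbon-only group, now a branched one without any ring, is therefore expected to lower the number again, though not certainly by the full amount. Compound 3 is estimated at 40 nM, with a likely range from 8 nM to 200 nM, meaning an expected step of a 14-fold lower number from compound 2 to compound 3 (1.15 log units; beyond the scatter).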

Compound 3, inhibition constant: 31 nM
The estimate for compound 3 lay 1.3-fold (0.11 log units) above the measured number; measured number inside the range.
By their numbers in this assay, from the lowest: compound 1; then compound 3; then compound 2.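

In this assay, replacing furan-2-yl with tert-butyl gives an 18-fold lower number from compound 2 to compound 3 (1.26 log units; beyond the scatter) and so shows that a group with no ring can sit on this aromatic carbon and still give a far lower number than the furan. Tert-butyl does not fully match the two-ring carbon group, with an 8.2-fold higher number from compound 1 to compound 3 (0.91 log units; beyond the scatter) marking a smaller but still real gap, so among these three compounds both carbon-only groups beat the furan and the two-ring group stands lowest. Nothing measured here explains this order.

Tert-butyl differs from furan-2-yl at once in its ring, its aromatic character and its oxygen atom, so these three features remain tangled. A cyclopentyl group or a tetrahydrofuran-2-yl group at this place would help to separate them.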